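The compounds below may be only part of what the source reports. "The series", "measured", "known", "first", "only" and "open" are said of these compounds alone.

Compound 3 `N#Cc1c(-c2ccc(N3CCCCC3)cc2)ccn2c(CC(F)(F)F)cnc12` stands lowest of the three compounds measured in a functional assay on CHO cells with metabotropic glutamate receptor 2 (Homo sapiens) as the target, read by GTPgammaS binding; on this read-out higher numbers stand for larger maximal responses and lower numbers for smaller maximal responses: compound 3 gives 123%, whereas compound 1 `CCCCn1ccc(N2CCN(c3nc(C)cc(C)n3)CC2)c(C#N)c1=O` gives 235% and compound 2 `CC(C)(C)c1ccc(-c2ccn3c(CC(F)(F)F)cnc3c2C#N)cc1` gives 272%. For the measured compounds named here, the only measured step that changes a single place is a number 149 percentage points lower from compound 2 to compound 3 (beyond the scatter), a large fall that accompanied piperidin-1-yl in place of tert-butyl on an aromatic carbon. Compound 4 `N#Cc1c(-c2ccc(Oc3ccccc3)cc2)ccn2c(CC(F)(F)F)cnc12` moves away from compound 3 at that same place: phenoxy in place of piperidin-1-yl on an aromatic carbon, on an aromatic carbon of a six-membered aromatic ring of carbon only, para to a large group. Going by the values given here, no measured compound carries a phenoxy group, so that step gives the sole bearing: the piperidin-1-yl that came with the large fall leaves again, and a partial return toward the level of compound 2 seems plausible, although the new group is not tert-butyl. The step expected in this assay is therefore upward, about a number 67 percentage points higher from compound 3 to compound 4 (beyond the scatter), with wide uncertainty. Compound 4 is estimated at 190% in this assay, within a range of 110% to 270%.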

Compound 4, largest response reached (Emax), in percent of the reference or control that the assay uses: 200%
For compound 4 the middle estimate is 10 percentage points below the measured one; the range from low to high includes it.
By their numbers in this assay, from the lowest: compound 3; then compound 4; then compound 1; then compound 2.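

In this assay, this place, on an aromatic carbon of a six-membered aromatic ring of carbon only and para to a large group, can now be compared across three groups on the shared core. The step of a number 77 percentage points higher from compound 3 to compound 4 (beyond the scatter) shows that the low level of compound 3 does not extend to every six-membered ring at this place, while the step of a number 72 percentage points lower from compound 2 to compound 4 (beyond the scatter) shows that phenoxy does not restore the level reached with tert-butyl, so the three groups give three levels, each separated by steps beyond the scatter. Nothing given here explains this order.

The compounds shown leave open how a morpholine ring, a methoxy group or a carboxylic acid would read at this place. They also leave open whether the order of the three groups would hold if the nitrile were replaced by an amide.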